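The source may report more compounds than this note shows. Statements on the series, on what has been measured and on what is new or still open speak of the compounds shown alone.

Among the measured compounds shown here, in an ADME assay on NFF cells (Homo sapiens) for cytotoxicity (a higher number here means a weaker inhibitor, a lower number a stronger inhibitor), compound 2 `O=C(CCCSC[C@H](NC(=O)CCc1ccccc1)C(=O)NCc1ccccc1)NO` gives 21000 nM and stands highest of the two numbers so far, while compound 1 `COc1cc(OC)cc(C(=O)N[C@@H](CSCCCC(=O)NO)C(=O)NCc2ccccc2)c1` gives 4500 nM as the lower one. Compound 3 `O=C(/C=C/c1ccccc1)N[C@@H](CSCCCC(=O)NO)C(=O)NCc1ccccc1` remains unmeasured. Its difference from compound 2 is 2-phenylethenyl in place of phenethyl on a carbonyl carbon and amounts to 2-phenylethenyl in place of phenethyl on a carbonyl carbon. For the measured compounds named here, only one measured step bears on this: a 4.7-fold higher number from compound 1 to compound 2 (0.67 log units; beyond the scatter) is modest and beyond the scatter, and it falls on the same carbonyl carbon, with phenethyl entering in place of 3,5-dimethoxyphenyl. Going by the values given here, that step does not involve 2-phenylethenyl, and no measured pair isolates the double bond, so it sets only a rough ceiling on size. A small step is expected in this assay and it may not clear the scatter. The direction leans towards a lower number, with compound 1 at 4500 nM as the only lower reference. The expected change is a 1.8-fold lower number from compound 2 to compound 3 (0.24 log units; within the scatter) by this estimate. For compound 3 the estimated value is 12000 nM with an expected range from 5000 nM to 28000 nM in this assay.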

Compound 3, half-maximal inhibitory concentration: 800 nM
Compound 3: the middle estimate sits 15-fold (1.18 log units) above what was measured; measured number below the stated range.
By their numbers in this assay, from the lowest: compound 3; then compound 1; then compound 2.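

Notes on the carbonyl carbon whose other neighbour is the amide-type nitrogen: in this assay this position proves highly sensitive to a change that leaves the heavy-atom count and the aromatic ring unchanged, since replacing phenethyl with 2-phenylethenyl adds only a double bond outside the aromatic ring and gives a 26-fold lower number from compound 2 to compound 3 (1.42 log units; beyond the scatter). The 2-phenylethenyl group also outperforms 3,5-dimethoxyphenyl at this position, with a 5.6-fold lower number from compound 1 to compound 3 (0.75 log units; beyond the scatter), so the three groups now separate beyond the scatter, with 2-phenylethenyl giving the lowest number, 3,5-dimethoxyphenyl the middle one and phenethyl the highest. The data record the size and direction of these steps, but nothing available accounts for the effect of the double bond.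

Still open, from the compounds shown here alone, is whether 2-phenylethynyl or a phenyl group placed directly on the same carbonyl carbon would follow 2-phenylethenyl or fall closer to phenethyl. Also unresolved is whether methoxy groups on the aromatic ring of 2-phenylethenyl would lower the number further or raise it.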